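Adding a second methyl to the phenyl group

The source may hold more compounds than are shown below. What is called first, only, known or untested is meant among the compounds shown, and "the series" means these compounds.

Of the compounds shown here, three sharing one core have been measured in a functional assay on A-431 cells (Homo sapiens) for cytotoxicity; a lower number here means that less compound is needed, a higher number that more compound is needed for the effect. Compound 1 `COC1=C(C)C(=O)/C(=C(O)/C=C/c2ccccc2OC)C(=O)C1(C)C` gives 6.6 ug/mL, compound 2 `COC1=C(C)C(=O)/C(=C(O)/C=C/c2ccc(O)cc2)C(=O)C1(C)C` gives 14.9 ug/mL, and compound 3 `COC1=C(C)C(=O)/C(=C(O)/C=C/c2ccc(C)cc2)C(=O)C1(C)C` gives 5.1 ug/mL. The step of a 1.3-fold lower number from compound 1 to compound 3 (0.11 log units; within the scatter) stays within the scatter, so those two stand level, while the step of a 2.9-fold lower number from compound 2 to compound 3 (0.47 log units; beyond the scatter) goes beyond it.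

Compound 4 `COC1=C(C)C(=O)/C(=C(O)/C=C/c2c(C)cccc2C)C(=O)C1(C)C` is not yet measured. It has 2,6-dimethylphenyl in place of 4-methylphenyl on a double-bonded chain carbon bound to a double-bonded chain carbon.

The closest guide is the swap of one hydroxy-free phenyl group for another, a 1.3-fold lower number from compound 1 to compound 3 (0.11 log units; within the scatter). The other step from compound 1, a 2.3-fold higher number from compound 1 to compound 2 (0.35 log units; beyond the scatter), is modest and brings in a hydroxy group, which compound 4 lacks. Among the compounds with values here, no measured compound carries 2,6-dimethylphenyl, so the uncertainty stays wide. The expected change is a 1.2-fold higher number from compound 3 to compound 4 (0.07 log units; within the scatter), which would be no step beyond the scatter in this assay. For compound 4 the estimated value is 6 ug/mL, with an expected range from 2.5 ug/mL to 14 ug/mL.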

Compound 4, concentration for half-maximal effect: 10.1 ug/mL
Compound 4: middle estimate off by 1.7-fold (0.23 log units), on the low side, within the range that was stated.
By their numbers in this assay, from the lowest: compounds 3, 1, 4 and 2 (each within the scatter of the next, the first and the last beyond it).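

At this position on the chain, 2,6-dimethylphenyl takes the place of 4-methylphenyl without a change beyond the scatter (a 2.0-fold higher number from compound 3 to compound 4 (0.30 log units; within the scatter)), so a phenyl group with two methyls stands level with one carrying a single methyl. The new compound also stands level with the two other measured compounds (a 1.5-fold lower number from compound 2 to compound 4 (0.17 log units; within the scatter); a 1.5-fold higher number from compound 1 to compound 4 (0.18 log units; within the scatter)), even though the 4-hydroxyphenyl and 4-methylphenyl compounds lie apart (a 2.9-fold lower number from compound 2 to compound 3 (0.47 log units; beyond the scatter)), so it fits with either side of that gap. Nothing available here explains these values.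

The compounds shown leave open how an amine or a carboxylic acid on the phenyl group would behave at this position. They also leave open whether a longer chain in place of the methoxy group on the shared core would shift the numbers beyond the scatter.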